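Swapping a Furan for a Cyanothiophene: Solubility Outlook

The source may report more compounds than this note shows. Statements on the series, on what has been measured and on what is new or still open speak of the compounds shown alone.

Compound 3 `CC(C)CN1C(=O)c2ccccc2[C@H](C(=O)Nc2ccc(F)c(C#N)c2)[C@H]1c1ccco1` sits at the lower end of the three numbers in a physicochemical assay for solubility, in phosphate buffer, with a stated time of 18 h, at pH 7 (on this read-out lower numbers stand for lower solubility and higher numbers for higher solubility), giving 13000 nM. Compound 2 `CC(C)CN1C(=O)c2ccccc2[C@H](C(=O)Nc2ccc(F)c(C#N)c2)[C@H]1c1ccoc1` gives 15000 nM in this assay, and the step of a 1.2-fold lower number from compound 2 to compound 3 (0.06 log units; within the scatter) is within the scatter, so the two cannot be ranked. Compound 1 `CC(C)CN1C(=O)c2ccccc2[C@H](C(=O)Nc2ccc(F)c(C#N)c2)[C@H]1C1CCCNC1` gives 54000 nM, and both a 3.6-fold lower number from compound 1 to compound 2 (0.56 log units; beyond the scatter) and a 4.2-fold lower number from compound 1 to compound 3 (0.62 log units; beyond the scatter) are clearly beyond the scatter.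

Compound 4 `CC(C)CN1C(=O)c2ccccc2[C@H](C(=O)Nc2ccc(F)c(C#N)c2)[C@H]1c1ccc(C#N)s1` differs from compound 3 in one place: 5-cyanothiophen-2-yl in place of furan-2-yl on a saturated ring carbon. Among the measured compounds shown here, no measured step exchanges one five-membered aromatic ring for another that carries a nitrile, so the only guidance is indirect. The two steps that go beyond the scatter, a 3.6-fold lower number from compound 1 to compound 2 (0.56 log units; beyond the scatter) and a 4.2-fold lower number from compound 1 to compound 3 (0.62 log units; beyond the scatter), both run downward when a five-membered aromatic ring takes the place of piperidin-3-yl, while the furan-to-furan step a 1.2-fold lower number from compound 2 to compound 3 (0.06 log units; within the scatter) moves nothing. On that basis a modest downward step a 2.2-fold lower number from compound 3 to compound 4 (0.34 log units; beyond the scatter) is expected for compound 4 in this assay, and its solubility is estimated at 6000 nM, within a range of 2000 nM to 15000 nM.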

Compound 4, solubility: 4900 nM
For compound 4 the middle estimate is 1.2-fold (0.09 log units) above the measured one; low and high end bracket the measured number.
By their numbers in this assay, from the lowest: compound 4; then compounds 3 and 2 (each within the scatter of the next); then compound 1.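

In this assay, this position now shows a step beyond the scatter between two five-membered aromatic rings, a 2.7-fold lower number from compound 3 to compound 4 (0.42 log units; beyond the scatter) and likewise a 3.1-fold lower number from compound 2 to compound 4 (0.49 log units; beyond the scatter), whereas the two furans could not be ranked. Alongside an 11-fold lower number from compound 1 to compound 4 (1.04 log units; beyond the scatter), this puts compound 4 lowest of the four, so the aromatic groups at this saturated ring carbon do not all read alike. Nothing measured here accounts for the step.

The change replaces the ring oxygen with sulfur and adds a nitrile at once, and with neither an unsubstituted thiophen-2-yl nor a 5-cyanofuran-2-yl among the compounds shown, the two changes cannot be separated. Also open, from the compounds shown here alone, is how an amine or a carboxylic acid on the five-membered ring would read at this position.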